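Swapping a Phenyl for a Pyridine on a Stable-Looking Core

A few compounds are considered here, and "the series" means these few. Any claim that something is new, unique, unknown or untested is made for them only; others in the source may bear on it.

Compound 2, `COc1ccc(-n2cnc3cnc(-c4ccc(F)cc4C)cc32)cc1`, is the starting point for this step. In an ADME assay on S9 fraction from liver (Mus musculus) for metabolic stability, read by LC-MS, using NADPH, with a stated time of 45 min, tested at 3 uM, in the presence of a further agent that is not named here (a lower number here means that the liver removes a smaller share, a higher number that the liver removes a larger share of the compound in one pass), compound 2 gives 1, so nearly all of it is cleared in one pass. Its closest measured relative, compound 1, `COc1ccc(-n2cnc3cnc(-c4ccc(F)cc4C)cc32)cc1OC`, carries an extra methoxy group on the same ring, and in this assay compound 1 gives 1. The step from compound 1 to compound 2 is no change at the digits printed from compound 1 to compound 2 (within the scatter), a change that stays within the scatter. A third relative, compound 3, `COc1ccc(-n2cnc3cnc(-c4ccc(F)cc4C)cc32)cc1Cl`, has in this assay only the entry "not determined" (no result reported), so no number is available for it.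

Compound 4, `COc1ccc(-n2cnc3cnc(-c4ccc(F)cc4C)cc32)nc1`, has not yet been measured. Its difference from compound 2 is 5-methoxypyridin-2-yl in place of 4-methoxyphenyl on an aromatic nitrogen. Among the measured compounds shown here, no measured step involves this kind of change, so the only guide is that both measured compounds sit at the top of the scale. The step from compound 2 to compound 4 is therefore expected to be a number 0.050 lower from compound 2 to compound 4 (within the scatter), that is, no movement beyond the scatter. Compound 4 is estimated at 0.95 in this assay, within a range of 0.8 to 1.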

Compound 4, hepatic extraction ratio: 0.66
Compound 4: middle estimate off by 0.29, on the high side, outside the stated range (below it).
By their numbers in this assay, from the lowest: compound 4; then compounds 1 and 2 (each within the scatter of the next).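

Exchanging 4-methoxyphenyl for 5-methoxypyridin-2-yl on the aromatic nitrogen gives a number 0.34 lower from compound 2 to compound 4 (beyond the scatter) in this assay and so brings a compound in this small set off the top of the scale. Among the compounds shown here, compounds 1 and 2 both sit at the top of the scale and show no such movement, so only this new step reveals that the ring at this position can alter the reading. The data offer no measurement that explains why this exchange has such an effect.

On these data alone, it remains open whether a second ring nitrogen, as in a pyrimidine, would shift the reading further. As far as these compounds go, it is equally open whether the pyridine ring would hold this lower reading with an amine or a carboxylic acid in place of the methoxy group.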